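Dropping One Trifluoromethyl from a Urea Tail

A few compounds are considered here, and "the series" means these few. Any claim that something is new, unique, unknown or untested is made for them only; others in the source may bear on it.

Two measured compounds share a core with a urea-linked aryl group. Compound 1 `O=C(Nc1cccc(-n2cc(-c3ccncc3)c(-c3cc(O)cc(Cl)c3)n2)c1)Nc1ccc(Cl)c(C(F)(F)F)c1` and compound 2 `COc1cc(Cl)cc(-c2nn(-c3cccc(NC(=O)Nc4cc(C(F)(F)F)cc(C(F)(F)F)c4)c3)cc2-c2ccncc2)c1` were tested in a functional assay on HOP-62 cells (Homo sapiens) for inhibition, read by sulforhodamine B assay, with a stated time of 48 h, tested at 1 uM; on this read-out higher numbers stand for a weaker effect at the one concentration tested and lower numbers for a stronger effect. Compound 1 gives 96% in this assay, whereas compound 2 gives 40%. Of these two numbers compound 2 stands lowest, and the gap to its nearest neighbour, compound 1, lies beyond the scatter, so compound 2 shows the stronger effect here. Compound 3 `COc1cc(Cl)cc(-c2nn(-c3cccc(NC(=O)Nc4cccc(C(F)(F)F)c4)c3)cc2-c2ccncc2)c1` has not yet been measured; it differs from compound 2 in one place: hydrogen in place of trifluoromethyl on an aromatic carbon. Among the compounds with values here, no measured pair shows this exact change, so its size cannot be read from the data; the one comparison available, compound 1 at 96%, shows only that the urea tail matters. The expected step of a number 20 percentage points higher from compound 2 to compound 3 (beyond the scatter) is modest and towards a weaker effect, though it could lie within the scatter. Compound 3 is expected to give 60%, with a range from 35% to 90%.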

Compound 3, a percentage reported as activity, at one concentration (the size of the read-out at that concentration, not a potency): 85%
Beside the measured number, compound 3's estimate is 25 percentage points below it; low and high end bracket the measured number.
By their numbers in this assay, from the lowest: compound 2; then compound 3; then compound 1.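

Within the data shown here, the read-out in this assay shows a number 45 percentage points higher from compound 2 to compound 3 (beyond the scatter) when trifluoromethyl gives way to hydrogen on this aromatic carbon, and this is the first change in one place whose size can be read. The position therefore matters a great deal: with the second trifluoromethyl present the effect at the one concentration tested is clearly stronger, and removing that single group leaves a much weaker effect. Nothing measured here accounts for the size of this step.

Only trifluoromethyl and hydrogen are shown at this carbon, so it stays open whether a methyl group, a nitrile or a methoxy group would keep the stronger effect. On these data alone, compound 1 differs from compound 2 and compound 3 in more than one place, so whether the step would hold with the hydroxyl of compound 1 on the shared core also remains open.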